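A few compounds are considered here, and "the series" means these few. Any claim that something is new, unique, unknown or untested is made for them only; others in the source may bear on it.

Measured compounds in a functional assay on P388 cells (Mus musculus) for inhibition, tested at 100 uM; on this read-out lower numbers stand for a weaker effect and higher numbers for a stronger effect at the one concentration tested:
- compound 1 `COc1ccc2c(c1)c(-c1cc(C(F)(F)F)ccn1)cn2S(=O)(=O)c1ccc(C)cc1`: 15.6%
- compound 2 `Cc1ccc(S(=O)(=O)n2cc(-c3cc(C(F)(F)F)cc(-c4cn(S(=O)(=O)c5ccc(C)cc5)c5ccccc45)n3)c3ccccc32)cc1`: 14.7%
- compound 3 `COc1ccc2c(-c3cc(C(F)(F)F)cc(-c4cn(S(=O)(=O)c5ccc(C)cc5)c5cc(OC)ccc45)n3)cn(S(=O)(=O)c3ccc(C)cc3)c2c1`: 99.9%

Compound 1 stands second highest of the three numbers in this assay. Its nearest neighbour is compound 2, whose value lies lower by an amount within the usual scatter, so the two cannot be ranked against each other. Compound 3 lies far higher, a gap well beyond the scatter, and is the only one of the three with a strong effect at the concentration tested. Within the data shown here, no single-point step between any two of the measured compounds has been worked out, so nothing more can be said of the pairs than what their values show.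

The next compound, compound 4 `Cc1ccc(S(=O)(=O)n2cc(-c3cc(C(F)(F)F)ccn3)c3cc(Br)ccc32)cc1`, is derived from compound 1 by one change: bromo in place of methoxy on an aromatic carbon. Among the measured compounds shown here, no measured pair illustrates this kind of change, so there is no precedent on which to size the step. Compounds 1 and 2, which share the same single core unit, both give a weak read-out, and a substituent swap on that unit is expected to leave the number near that level. The step from compound 1 to compound 4 in this assay is therefore expected to be small, in either direction, most likely none beyond the scatter, a number 4.4 percentage points higher from compound 1 to compound 4 (within the scatter). For compound 4 the estimate in this assay is 20%, within a range from 4% to 50%.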

Compound 4, a percentage reported as inhibition, at one concentration (the size of the read-out at that concentration, not a potency): 32.6%
Beside the measured number, compound 4's estimate is 12.6 percentage points below it, and the stated range covers the measured number.
By their numbers in this assay, from the lowest: compounds 2 and 1 (each within the scatter of the next); then compound 4; then compound 3.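

In this assay, bromo in place of methoxy on an aromatic carbon of the fused system gives a number 17 percentage points higher from compound 1 to compound 4 (beyond the scatter), a modest step. Among these compounds, this is the first pair that differs in one place only, so it is the first direct sign that the read-out of the core of compound 1 responds to a change at this carbon. The exchange removes a group of two heavy atoms with one hydrogen-bond acceptor and puts in a single bromine with none, but no data at hand tie the step to either of those differences or to any other feature of the two groups.

This single pair cannot show whether the step is specific to bromo or would appear with other groups at the same carbon, such as chloro, a hydroxyl, an amine or an ethoxy chain. It also leaves open whether the same exchange would give a step of similar size on the compounds that carry two core units.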